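This account rests on a few compounds, and the source may have more. Where it says the series, first, only, none or still open, it means among the compounds named here.

Working notes on the series. The compounds share one core: compound 1 is `COc1ccc(F)cc1C1CCN(c2ccn3c(CC(F)(F)F)nnc3c2Cl)CC1`, compound 2 is `COc1ccc(F)cc1C1CCN(c2ccn3c(CC4CC4)nnc3c2Cl)CC1` and compound 3 is `COc1cccc(F)c1C1CCN(c2ccn3c(CC4CC4)nnc3c2Cl)CC1`. In an ADME assay on a cell-free system (plasma, Homo sapiens) for protein binding (on this read-out higher numbers stand for a larger free fraction and lower numbers for a smaller free fraction), compound 1 gives < 0.01, which is a limit of the assay and not a number. In this assay compound 2 gives < 0.01, again a limit. In this assay compound 3 gives < 0.01, also a limit. The step that the two limits leave unreadable from compound 1 to compound 2 and the step that the two limits leave unreadable from compound 2 to compound 3 therefore carry no readable size. All three values sit at the limit of < 0.01 in this assay, at which 3 of the 3 values shown sit, so compound 3 stands only as a limit, with no number to set it against the other two.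

Compound 4 is `COc1c(C2CCN(c3ccn4c(CC5CC5)nnc4c3Cl)CC2)ccc(F)c1F`; the change from compound 3 is 3,4-difluoro-2-methoxyphenyl in place of 2-fluoro-6-methoxyphenyl on a saturated ring carbon. Of the measured steps, a step that the two limits leave unreadable from compound 2 to compound 3 touches the same position and is unreadable, and a step that the two limits leave unreadable from compound 1 to compound 2 is unreadable as well, so no size can be read from either for this assay. Every value recorded so far in this assay has come back as a limit. Compound 4 is therefore expected to sit at that limit too, with an estimated unbound fraction of 0.005 and a range from 0.002 to 0.012. The step that the limit leaves unreadable from compound 3 to compound 4 that this estimate implies is expected to be within the scatter, with a further limit the most likely report.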

Compound 4, unbound fraction: < 0.01
Compound 4: no number, only a limit; the forecaster's own chance of this, stated with the estimate: 85%; the middle value is on the limit's open side.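

In this assay compound 4 gives < 0.01, a limit of the assay and not a number. No new step can be read, either from compound 2 to compound 4 or from compound 3 to compound 4. The compounds shown leave open whether any of the changes across compound 1, compound 2, compound 3 and compound 4 alters the unbound fraction, with every value at one limit: the limit of < 0.01 in this assay, at which 4 of the 4 values shown sit.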